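Swapping One Aryl Group on a Weakly Cytotoxic Compound

The compounds below may be only part of what the source reports. "The series", "measured", "known", "first", "only" and "open" are said of these compounds alone.

In a functional assay on PC-3 cells (Homo sapiens) for cytotoxicity, read by MTT assay, with a stated time of 72 h (a lower number here means a stronger inhibitor, a higher number a weaker inhibitor), two related compounds have been measured so far. Compound 1 `O=C(N/N=C/c1ccc(O)cc1O)Nc1cc2c(Nc3ccc(F)c(Cl)c3)ncnc2cc1O[C@H]1CCOC1` gives 7540 nM, and compound 2 `COc1ccc(/C=N/NC(=O)Nc2cc3c(Nc4ccc(F)c(Cl)c4)ncnc3cc2OC)cc1` gives 16500 nM, the higher number of the pair and so the weaker result. Compound 3 `COc1cc2ncnc(Nc3ccc(F)c(Cl)c3)c2cc1NC(=O)N/N=C/c1ccc(O)cc1O` keeps the core of compound 2 and changes one group: 2,4-dihydroxyphenyl in place of 4-methoxyphenyl on a carbon with a double bond to nitrogen. Within the data shown here, compound 1, at 7540 nM, already carries 2,4-dihydroxyphenyl, but its core also differs, so no measured pair shows this swap alone. A small drop in this assay is therefore expected, an estimated 1.8-fold lower number from compound 2 to compound 3 (0.26 log units; within the scatter). For compound 3 the expected value is 9000 nM, with an estimated range of 3500 nM to 22000 nM.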

Compound 3, half-maximal inhibitory concentration: 29500 nM
The estimate for compound 3 lay 3.3-fold (0.52 log units) below the measured number; measured number above the stated range.
By their numbers in this assay, from the lowest: compound 1; then compounds 2 and 3 (each within the scatter of the next).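

In this assay, the exchange of 4-methoxyphenyl for 2,4-dihydroxyphenyl on a carbon with a double bond to nitrogen can now be read alone: a 1.8-fold higher number from compound 2 to compound 3 (0.25 log units; within the scatter) means that this exchange does not separate the two compounds on this core. With 2,4-dihydroxyphenyl held constant, methyl in place of oxolan-3-yl on an oxygen on an aromatic ring gives a 3.9-fold higher number from compound 1 to compound 3 (0.59 log units; beyond the scatter), so of these two single changes, only this one is beyond the scatter. Nothing available gives a reason for either step.

As far as these compounds go, it remains open whether 4-methoxyphenyl would give the same result on the core of compound 1. Also open, from the compounds shown here alone, is how a phenyl ring carrying a single hydroxyl would read at the first place, or a longer chain ending in an amine on that oxygen.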